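Dichloro oxime series: expected shift from compound 3 to compound 4

The source may report more compounds than this note shows. Statements on the series, on what has been measured and on what is new or still open speak of the compounds shown alone.

Working notes on a small set of oxime-bearing styryl compounds tested in a functional assay (Mus musculus, strain Balb/c) for inhibition, read by ELISA, with a stated time of 72 h; on this read-out higher numbers stand for weaker inhibition and lower numbers for stronger inhibition. Compound 1 `O/N=C(\C=C\c1ccc(Cl)cc1)c1ccc(Br)cc1` gives 14700 nM. Compound 2 `O/N=C(\C=C\c1ccc(Cl)c(Cl)c1)c1ccc(Br)cc1` is reported only as a limit of the assay, < 5000 nM, not as a number. Compound 3 `Cc1ccc(C(/C=C/c2ccc(Cl)cc2)=N/O)cc1` gives 11600 nM in this assay, and with a 1.3-fold lower number from compound 1 to compound 3 (0.10 log units; within the scatter) it sits alongside compound 1 rather than apart from it. Within the data shown here, compound 2 is the only other member and offers a limit rather than a number (the limit of < 5000 nM in this assay, at which 1 of the 3 values shown sits).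

Compound 4 `Cc1ccc(C(/C=C/c2ccc(Cl)c(Cl)c2)=N/O)cc1` is not yet measured. It differs from compound 3 as follows: chloro in place of hydrogen on an aromatic carbon. Among the measured compounds shown here, the one measured step of the same kind is an at least 2.9-fold lower number from compound 1 to compound 2 (0.46 log units; beyond the scatter), and that step is a minimum because compound 2 was reported only at the limit. Applying a step of the same size to compound 3, a lower number is expected for compound 4 in this assay, and the estimated step of a 3.0-fold lower number from compound 3 to compound 4 (0.47 log units; beyond the scatter) is taken to be at least modest, with a clear chance that the result is again returned only as a limit. The estimate for compound 4 in this assay is 3900 nM, expected to fall between 1500 nM and 10000 nM.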

Compound 4, half-maximal inhibitory concentration: 6340 nM
Compound 4: middle estimate off by 1.6-fold (0.21 log units), on the low side; low and high end bracket the measured number.
By their numbers in this assay, from the lowest: compounds 4, 3 and 1 (each within the scatter of the next, the first and the last beyond it). At a limit, below all of these: compound 2.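

On the core of compound 3, chloro in place of hydrogen on an aromatic carbon, ortho to a chloro group, gives in this assay a 1.8-fold lower number from compound 3 to compound 4 (0.26 log units; within the scatter), so this change now has a step that is a full measured number, and that step lies within the scatter rather than beyond it: the same change on two cores in this assay, an at least 2.9-fold lower number (0.46 log units; beyond the scatter) from compound 1 to compound 2 and a 1.8-fold lower number (0.26 log units; within the scatter) from compound 3 to compound 4; the limit leaves it open whether they differ
Compound 2, at < 5000 nM, is a limit of the assay and not a number.
Methyl in place of bromo on an aromatic carbon can now also be read with the added chloro present, as an at least 1.2-fold higher number from compound 2 to compound 4 (0.10 log units; that floor lies within the scatter), which is only a floor, so this exchange shows no step beyond the scatter on either core so far, though the size of the second step stays unsettled: the same change on two cores in this assay, a 1.3-fold lower number (0.10 log units; within the scatter) from compound 1 to compound 3 and an at least 1.2-fold higher number (0.10 log units; that floor lies within the scatter) from compound 2 to compound 4; the limit leaves it open whether they differ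

The data do not show how a group other than chloro at this position, such as an amine or a carboxylic acid, would move the number on the core of compound 3. The four compounds also leave open what a nitrile or a longer chain would do in the place held by methyl and bromo.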